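Swapping methyl for tert-butyl on the shared core

The source may hold more compounds than are shown below. What is called first, only, known or untested is meant among the compounds shown, and "the series" means these compounds.

Compound 2 `Cc1cc(NC(=O)c2ccc(C)c(Nc3nc(-c4cccnc4)cs3)c2)cc(-n2cnc(C)c2)c1` carries a methyl group where compound 1 `Cc1cn(-c2cc(NC(=O)c3ccc(C)c(Nc4nc(-c5cccnc5)cs4)c3)cc(C(F)(F)F)c2)cn1` carries a trifluoromethyl group. Among the measured compounds shown here, in a functional assay on K562 cells (Homo sapiens) for antiproliferative activity (on this read-out higher numbers stand for weaker inhibition and lower numbers for stronger inhibition), compound 2 gives 449 nM, the highest of the two numbers measured so far, while compound 1 gives 28 nM; the change was a 16-fold higher number from compound 1 to compound 2 (1.21 log units; beyond the scatter). Compound 3 `Cc1cn(-c2cc(NC(=O)c3ccc(C)c(Nc4nc(-c5cccnc5)cs4)c3)cc(C(C)(C)C)c2)cn1` is the next step from compound 2: tert-butyl in place of methyl on an aromatic carbon. For the measured compounds named here, the only measured step at this position concerns a different exchange, so it bears on compound 3 only loosely; it shows that this position can move this assay strongly, but not which way a larger alkyl group would push it. The expected change is therefore uncertain, with a modest lean toward a lower number, a 2.5-fold lower number from compound 2 to compound 3 (0.40 log units; beyond the scatter). Compound 3 is estimated at 180 nM, within a range from 40 nM to 800 nM.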

Compound 3, half-maximal inhibitory concentration: 10 nM
Compound 3: the middle estimate sits 18-fold (1.26 log units) above what was measured, and the stated range ends above it.
By their numbers in this assay, from the lowest: compound 3; then compound 1; then compound 2.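

In this assay, among the compounds shown here, the size of the alkyl group at this position matters greatly: tert-butyl in place of methyl gives a 45-fold lower number from compound 2 to compound 3 (1.65 log units; beyond the scatter), a much larger shift than the one step known before. Trifluoromethyl is also not needed for a low number here, since the all-carbon tert-butyl group gives a 2.8-fold lower number from compound 1 to compound 3 (0.45 log units; beyond the scatter), so compound 3 has the lowest number of the three. Nothing available explains these differences.

The three compounds leave open where an ethyl or isopropyl group would fall between methyl and tert-butyl, since only the two ends of that alkyl series are shown. They also leave open whether a methoxy group or an amine at this position could give a number as low as that of compound 3.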